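The source may hold more compounds than are shown below. What is called first, only, known or untested is meant among the compounds shown, and "the series" means these compounds.

Compound 1 `CN(C)c1ccc(C(=O)N[C@H]2CCC[C@H](NC(=O)c3cccc(Cl)c3)C2)cc1` is the starting point of this account. Among the measured compounds shown here, in a functional assay on HEK293 cells for antagonist activity at metabotropic glutamate receptor 5 (Homo sapiens), read by FLIPR and calcium flux (on this read-out lower numbers stand for stronger inhibition and higher numbers for weaker inhibition), compound 1 gives 473 nM, and that is the only number the set shows. For the measured compounds named here, the one further value belongs to compound 2 `N#Cc1cccc(C(=O)N[C@@H]2CCC[C@H](NC(=O)c3ccccn3)C2)c1` and is a limit rather than a number. In this assay compound 2 returns > 10000 nM, a limit of the assay and not a measured number, so that the limit of > 10000 nM in this assay, at which 1 of the 2 values shown sits, describes where one of the two values sits.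

Compound 3 `Cc1cccc(C(=O)N[C@H]2CCC[C@H](NC(=O)c3cccc(Cl)c3)C2)n1` has not yet been measured in this assay. It differs from compound 1 in a single place: 6-methylpyridin-2-yl in place of 4-(dimethylamino)phenyl on a carbonyl carbon. The group that leaves is a six-membered aromatic ring of carbon only; the group that enters is a six-membered aromatic ring with one hetero atom, each with no hydrogen-bond donor and one hydrogen-bond acceptor.

Going by the values given here, no step between two measured compounds is available to guide the expectation, so it rests on compound 1 alone. The step of a 2.5-fold higher number from compound 1 to compound 3 (0.40 log units; beyond the scatter) is expected to lie beyond the usual scatter, in the direction of weaker inhibition. Compound 3 is therefore estimated at 1200 nM, with a range from 250 nM to 8000 nM.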

Compound 3, half-maximal inhibitory concentration: 290 nM
Compound 3: middle estimate off by 4.1-fold (0.62 log units), on the high side; measured number inside the range.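

In this assay, the exchange on the carbonyl carbon gives a 1.6-fold lower number from compound 1 to compound 3 (0.21 log units; within the scatter). Among the compounds shown here, this is the first one-place comparison in the set, and it shows that 6-methylpyridin-2-yl can take the place of 4-(dimethylamino)phenyl with no difference that stands out from repeat measurement, so for these two groups neither the carbon-only ring nor the dimethylamino group is needed to keep the read-out in this range. Nothing shown here bears on why the two groups read alike.

Going by these compounds, the step exchanges the ring and its substituent together, so it stays open what a plain pyridin-2-yl without the methyl, or a ring carrying a primary amine or a carboxylic acid, would give on this carbonyl carbon. On these data alone, compound 2 gives > 10000 nM, a limit of the assay and not a number, and it differs from the other two compounds in more than one place, so what each of those places contributes also stays open.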